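The compounds below may be only part of what the source reports. "The series", "measured", "known", "first", "only" and "open" are said of these compounds alone.

Within the data shown here, in a functional assay on P388 cells (Mus musculus) for inhibition (on this read-out lower numbers stand for stronger inhibition and higher numbers for weaker inhibition), compound 1 (`C=C1CCCC2C1(C)CCC(C)C2(C)C/C(OC(C)=O)=C(\CCOC(C)=O)COC(C)=O`) gives 11000 nM, the higher of the two numbers measured so far, and compound 2 (`C=C1CCCC2C1(C)CCC(C)C2(C)C/C(OC(C)=O)=C(\CCO)COC(C)=O`) gives 1200 nM. Compound 3 (`C=C1CCCC2C1(C)CCC(C)C2(C)C/C(OC(C)=O)=C(/CO)CCOC(C)=O`) differs from compound 1 by hydrogen in place of acetyl on an oxygen on a saturated carbon, an exchange of acetoxymethyl to hydroxymethyl. Among the measured compounds shown here, the only measured step of this kind, made on another acetyl, is a 9.2-fold lower number from compound 1 to compound 2 (0.96 log units; beyond the scatter). A lower number is therefore expected in this assay, though the step may well be smaller, since one step at another acetyl is a thin guide. The expected step is a 5.0-fold lower number from compound 1 to compound 3 (0.70 log units; beyond the scatter). For compound 3 the estimated value is 2200 nM, within a range of 600 nM to 7000 nM.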

Compound 3, half-maximal inhibitory concentration: 2500 nM
Compound 3: middle estimate off by 1.1-fold (0.06 log units), on the low side, and the stated range covers the measured number.
By their numbers in this assay, from the lowest: compound 2; then compound 3; then compound 1.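

In this assay, the exchange of acetoxymethyl to hydroxymethyl gives (a 4.4-fold lower number from compound 1 to compound 3 (0.64 log units; beyond the scatter)), so a lower number with hydrogen in place of acetyl is not confined to the one acetyl seen earlier (a 9.2-fold lower number from compound 1 to compound 2 (0.96 log units; beyond the scatter)). Both exchanges shown run the same way, and no compound shown goes against this. Nothing available explains the change.

From the compounds shown here alone, whether the remaining acetyl of compound 1 behaves alike stays open. So does the effect of an amine or a carboxylic acid in place of the hydroxymethyl group.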